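A few compounds are considered here, and "the series" means these few. Any claim that something is new, unique, unknown or untested is made for them only; others in the source may bear on it.

Compound 1 `Cn1cc(-c2ncc(C#N)c(N3C[C@@H]4C[C@H]3CN4CC3CC3)n2)cn1`: < 16 mL/min/kg
Compound 2 `Cn1cc(-c2ncc(C#N)c(N3C[C@@H]4C[C@H]3CN4S(=O)(=O)C3CC3)n2)cn1`: < 16 mL/min/kg

In an ADME assay on microsomes from liver (Homo sapiens) for pharmacokinetics (on this read-out higher numbers stand for fast clearance and lower numbers for slow clearance), compound 2 gives < 16 mL/min/kg, which is a limit and not a number. Compound 1 also gives only a limit. Compound 3 `Cn1cc(-c2ncc(C#N)c(N3C[C@@H]4C[C@H]3CN4C(=O)C3CC3)n2)cn1` carries cyclopropylcarbonyl in place of cyclopropylsulfonyl on an amine nitrogen in a ring. For the measured compounds named here, the one measured step is a step that the two limits leave unreadable from compound 1 to compound 2, so it offers no size to carry over. The closest guide is the limit of < 16 mL/min/kg in this assay, at which 2 of the 2 values shown sit. The expected change is therefore none beyond the usual scatter, and the estimated step is a step that the limit leaves unreadable from compound 2 to compound 3. Compound 3 is expected at 14 mL/min/kg, with an estimated range of 8 mL/min/kg to 24 mL/min/kg.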

Compound 3, clearance: < 16 mL/min/kg
Compound 3 ended at the assay's limit; the forecaster's own chance of this, stated with the estimate: 65%; the middle value is on the limit's open side.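

In this assay, for the compounds shown here, compound 1, compound 2 and compound 3 each give only a limit, so no step between them can be read. As far as these compounds go, whether cyclopropylmethyl, cyclopropylsulfonyl and cyclopropylcarbonyl differ at all in clearance stays open.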